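The source may report more compounds than this note shows. Statements on the series, on what has been measured and on what is new or still open speak of the compounds shown alone.

Measured so far:
compound 1, `O=C(/C=C/c1ccc(Cl)cc1)Nc1cc(-c2ccc(Br)cc2)[nH]n1`, gives 1210 nM in a functional assay on A549 cells (Homo sapiens) for antiproliferative activity, read by MTT assay, with a stated time of 48 h; a lower number here means a stronger inhibitor, a higher number a weaker inhibitor
compound 2, `O=C(/C=C\c1ccc(C(F)(F)F)cc1)Nc1cc(-c2ccccc2)[nH]n1`, gives 880 nM
compound 3, `Cc1ccc(-c2cc(NC(=O)/C=C/c3ccc(Cl)cc3)n[nH]2)cc1`, gives 1490 nM

Compound 1 stands second highest of these three numbers, and both other compounds lie within the usual scatter of it, so no order among them can be claimed. Compound 4, `O=C(/C=C/c1ccccc1)Nc1cc(-c2ccc(Br)cc2)[nH]n1`, differs from compound 1 by hydrogen in place of chloro on an aromatic carbon. Going by the values given here, the only measured step that touches a single group is a 1.2-fold higher number from compound 1 to compound 3 (0.09 log units; within the scatter), a different swap, and it stayed within the scatter. Among the compounds with values here, no measured pair removes a chloro, so there is no direct guide. Compound 4 is therefore expected to sit close to compound 1, a step of a 1.2-fold higher number from compound 1 to compound 4 (0.06 log units; within the scatter), and its estimated value is 1400 nM, with a range from 700 nM to 2800 nM.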

Compound 4, half-maximal inhibitory concentration: 1440 nM
For compound 4 the middle estimate is 1.0-fold (0.01 log units) below the measured one; measured number inside the range.
By their numbers in this assay, from the lowest: compounds 2, 1, 4 and 3 (each within the scatter of the next).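

Changing 4-chlorophenyl to phenyl gives a 1.2-fold higher number from compound 1 to compound 4 (0.08 log units; within the scatter) in this assay, so at this position the chloro can be removed without a shift that stands out from the scatter. Going by these compounds alone, the earlier step from compound 1 to compound 3 was a swap in a different place, so this is the first reading at this one. Nothing shown here speaks to the reason. As far as these compounds go, whether an amine, a carboxylic acid or a longer chain at this position would move the number beyond the scatter remains open. So does whether removing the chloro from compound 3 would give a similar result.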